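Cytotoxicity of Dinitrophenyl Tetrazoles Bearing Halogenated Benzyl Groups

A few compounds are considered here, and "the series" means these few. Any claim that something is new, unique, unknown or untested is made for them only; others in the source may bear on it.

The series was examined in an ADME assay on CHO-K1 cells (Cricetulus griseus) for cytotoxicity, read by MTT assay, with a stated time of 24 h; on this read-out lower numbers stand for stronger inhibition and higher numbers for weaker inhibition. Compound 1 `O=[N+]([O-])c1cc(Sc2nnnn2Cc2ccccc2)cc([N+](=O)[O-])c1` gives 127000 nM in this assay. For compound 2 `CCCCCCCCCCCCn1nnc(-c2cc([N+](=O)[O-])cc([N+](=O)[O-])c2)n1` this assay reports only a limit, > 200000 nM, not a number. Compound 3 `O=[N+]([O-])c1cc(-c2nnn(Cc3ccc(Cl)cc3)n2)cc([N+](=O)[O-])c1` gives 170000 nM, the highest of the two numbers recorded, while its value and that of compound 1 lie within the usual scatter of each other. Compound 4 `O=[N+]([O-])c1cc(-c2nnn(Cc3cccc(Br)c3)n2)cc([N+](=O)[O-])c1` is not yet measured; it differs from compound 3 by 3-bromophenyl in place of 4-chlorophenyl on a saturated chain carbon bound to an aromatic nitrogen. For the measured compounds named here, with no measured step between two compounds, the expected step from compound 3 to compound 4 in this assay is no change at the digits printed from compound 3 to compound 4 (within the scatter), no more than the scatter. Compound 4 is therefore estimated at 170000 nM, between 85000 nM and 260000 nM.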

Compound 4, half-maximal inhibitory concentration: 29000 nM
Compound 4: middle estimate off by 5.9-fold (0.77 log units), on the high side; measured number outside the range, below it.
By their numbers in this assay, from the lowest: compound 4; then compounds 1 and 3 (each within the scatter of the next). At a limit, above all of these: compound 2.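

For the compounds shown here, replacing 4-chlorobenzyl with 3-bromobenzyl gives a 5.9-fold lower number from compound 3 to compound 4 (0.77 log units; beyond the scatter) in this assay, the first measured step. It shows that the number in this assay responds to a change in the aryl group on the saturated chain carbon bound to an aromatic nitrogen. Nothing available here accounts for the size of this step.

Because the halogen and its ring placement change together, the data cannot separate their contributions. On these data alone, how an amine or a carboxylic acid on that phenyl ring would read also remains open.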